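Swapping the ring on the thiocarbonyl carbon in compound 2

The compounds below may be only part of what the source reports. "The series", "measured", "known", "first", "only" and "open" are said of these compounds alone.

Compound 2 `N/C(=N\NC(=S)N1CCOCC1)c1ccccn1` is tested in a functional assay on HeLa cells (Homo sapiens) for cytotoxicity, read by MTT assay, with a stated time of 72 h, tested at 30 uM (a higher number here means more inhibition of growth at the concentration tested, a lower number less inhibition of growth), and gives 82.8%. Among the three compounds measured so far, compound 2 stands second highest. Its nearest neighbour is compound 1 `N/C(=N\NC(=S)N1CCOCC1)c1ccc(F)cn1`, which gives 84.5%, and the step of a number 1.7 percentage points lower from compound 1 to compound 2 (within the scatter) lies within the scatter. The furthest is compound 3 `Cc1ccnc(/C(N)=N/NC(=S)N2CCOCC2)c1`, which gives 45.2%; the step of a number 37.6 percentage points lower from compound 2 to compound 3 (beyond the scatter) is large and beyond the scatter.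

Compound 4 `N/C(=N\NC(=S)N1CCCC1)c1ccccn1` has not yet been measured. It differs from compound 2 in one place: pyrrolidin-1-yl in place of morpholin-4-yl on a thiocarbonyl carbon. Both measured steps concern the aromatic ring of the shared core, not the thiocarbonyl carbon, and all three measured compounds carry the same morpholin-4-yl group there. So no measured step speaks directly to this change, and the measured steps only show that a small change at the ring left the number unchanged, while a methyl group lowered it strongly. With no direct guide, a modest change in either direction is expected, and the estimated step is a number 10.8 percentage points lower from compound 2 to compound 4 (beyond the scatter). For compound 4 the expected value is 72%, with a range from 40% to 92%.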

Compound 4, percent growth inhibition at one concentration: 84.5%
Beside the measured number, compound 4's estimate is 12.5 percentage points below it; low and high end bracket the measured number.
By their numbers in this assay, from the lowest: compound 3; then compounds 2, 1 and 4 (each within the scatter of the next).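

In this assay, the first step measured at the thiocarbonyl carbon is a number 1.7 percentage points higher from compound 2 to compound 4 (within the scatter), on going from morpholin-4-yl to pyrrolidin-1-yl. So this position accepts a change of ring size from six-membered to five-membered, and the loss of the ring oxygen with its hydrogen-bond acceptor, without a shift in the number beyond the scatter, at least for this pair and at this one tested concentration. Nothing available explains why the number holds here.

On these data alone, one swap between two saturated rings says little about the position as a whole, so it remains open how a piperidin-1-yl ring, a piperazin-1-yl ring with its second nitrogen, or an open-chain group such as dimethylamino would fare on the same carbon. Also open, as far as these compounds go, is whether pyrrolidin-1-yl would behave the same way on a core carrying a fluoro or methyl group on the aromatic ring, given that a methyl group there made a large difference when morpholin-4-yl was present.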